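Trimming a methyl from a thioether: cytotoxicity outlook

A few compounds are considered here, and "the series" means these few. Any claim that something is new, unique, unknown or untested is made for them only; others in the source may bear on it.

Compound 2 `CC(C)CSc1nc(N)nc2c1ncn2/C=C1/CC1(CO)CO` and compound 1 `Nc1nc(OCC(F)(F)F)c2ncn(/C=C3/CC3(CO)CO)c2n1` share a core and differ in the group attached to it. In an ADME assay on MOLT-3 cells (Homo sapiens) for cytotoxicity, with a stated time of 7 days (on this read-out higher numbers stand for lower toxicity in this test and lower numbers for higher toxicity in this test), compound 1 gives > 20000 nM, which is a limit of the assay rather than a measured number. For compound 2 the result in this assay reads "not determined" (no result reported), so no number stands for it at all. The only anchor for this series is the limit of > 20000 nM in this assay, at which 1 of the 2 values shown sits, the limit at which compound 1 sits.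

Compound 3 `CCCSc1nc(N)nc2c1ncn2/C=C1/CC1(CO)CO` is compound 2 with one change: hydrogen in place of methyl on a saturated chain carbon bound to two saturated chain carbons. Stated another way, an isobutylsulfanyl group becomes a propylsulfanyl group. Such a small change is not expected to move the read-out in this assay beyond the usual scatter in either direction.

Compound 3 is therefore expected to give about 20000 nM in this assay, with a plausible range from 5000 nM to 80000 nM, and most likely only a limit will be reported.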

Compound 3, half-maximal cytotoxic concentration: > 20000 nM
Compound 3 was reported as a limit; the forecaster's own chance of this, stated with the estimate: 70%; the middle value lies on the limit itself.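

Compound 1 and compound 3 both give only a limit in this assay, not a number, so no step can be read between them, and compound 2 has no result to compare with compound 3. The compounds shown leave open where the true cytotoxic concentration of either limited compound lies: the limit of > 20000 nM in this assay, at which 2 of the 3 values shown sit.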